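The source may report more compounds than this note shows. Statements on the series, on what has been measured and on what is new or still open speak of the compounds shown alone.

Going by the values given here, compound 1 `Fc1ccccc1CN(Cc1nnn[nH]1)c1ccccc1` gives 1.28 in a physicochemical assay for lipophilicity, using the shake flask method, measured as octanol-water partition, with a stated time of 24 h, at 25 degrees C (a lower number here means a more polar compound, a higher number a more lipophilic compound), the lowest of the three numbers measured so far. Compound 3 `Cc1ccc(N(Cc2nnn[nH]2)Cc2ccc(Cl)cc2Cl)cc1` gives 1.99, and compound 2 `CCCCCCCCN(Cc1nnn[nH]1)c1ccccc1` gives 2.24. Among the compounds with values here, the only step between measured compounds that differ in one place is a number 0.96 log units higher from compound 1 to compound 2 (beyond the scatter), a far larger structural change than the one considered here. Compound 4 `Fc1ccc(CN(Cc2nnn[nH]2)c2ccccc2)c(F)c1` differs from compound 1 by fluoro in place of hydrogen on an aromatic carbon, on an aromatic carbon of a six-membered aromatic ring of carbon only. Within the data shown here, no measured step adds a fluoro group to a ring, so these data give no direct guide to its size. A small shift upward, within the scatter, is expected, a number 0.14 log units higher from compound 1 to compound 4 (within the scatter). Compound 4 is therefore estimated at 1.42, with a range from 1.15 to 1.7.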

Compound 4, partition coefficient: 1.36
For compound 4 the middle estimate is 0.06 log units above the measured one; low and high end bracket the measured number.
By their numbers in this assay, from the lowest: compounds 1 and 4 (each within the scatter of the next); then compounds 3 and 2 (each within the scatter of the next).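

At this position, para to a large group and meta to a fluoro group, fluoro in place of hydrogen on an aromatic carbon gives in this assay a number 0.08 log units higher from compound 1 to compound 4 (within the scatter), so the two compounds cannot be told apart here. This single-atom change stays within the scatter, unlike the heptyl change, which gives a number 0.96 log units higher from compound 1 to compound 2 (beyond the scatter). No measurement at hand bears on why the fluoro step is this small. Going by these compounds, whether a trifluoromethyl group, a carboxylic acid or an amine at this position would give a step beyond the scatter remains open.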